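The compounds below may be only part of what the source reports. "The series", "measured", "known", "first", "only" and "open" are said of these compounds alone.

Among the compounds with values here, compound 1 `CC1(C)C/C(=N\NC(N)=O)c2cc(O)ccc2O1` is the weaker of the two compounds measured so far. In a functional assay on Vero cells (Chlorocebus sabaeus) for inhibition, with a stated time of 96 h (on this read-out lower numbers stand for stronger inhibition and higher numbers for weaker inhibition), compound 1 gives 170000 nM, the highest of the two numbers recorded. Within the data shown here, its closest neighbour is compound 2 `CCC1(C)C/C(=N\NC(N)=O)c2cc(O)ccc2O1`, which in this assay gives 50000 nM; the only change between them is a methyl in place of hydrogen on a saturated chain carbon bound to a saturated ring carbon, and that step, a 3.4-fold lower number from compound 1 to compound 2 (0.53 log units; beyond the scatter), is the only one measured here.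

Compound 3 `CC1(C)C/C(=N\NC(N)=S)c2cc(O)ccc2O1` differs from compound 1 in another place entirely: a group of 3 heavy atoms (1 carbon, 1 nitrogen, 1 sulfur; no ring) in place of a group of 3 heavy atoms (1 carbon, 1 nitrogen, 1 oxygen; no ring), on an amine nitrogen. Among the measured compounds shown here, no measured step touches this part of the molecule, so the step from compound 2 says nothing direct about it; the single measured change, on the saturated ring, moved the number only modestly. With no evidence on the sulfur-for-oxygen exchange, the expectation for compound 3 is a step of similar modest size, a 2.8-fold lower number from compound 1 to compound 3 (0.45 log units; beyond the scatter), in the direction of a lower number, but the range is kept wide. Compound 3 is therefore estimated at 60000 nM, with a likely span from 15000 nM to 250000 nM.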

Compound 3, half-maximal inhibitory concentration: 150000 nM
Compound 3: the middle estimate sits 2.5-fold (0.40 log units) below what was measured; the measured number falls inside the stated range.
By their numbers in this assay, from the lowest: compound 2; then compounds 3 and 1 (each within the scatter of the next).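

In this assay, exchanging the oxygen of the carbamoyl group for sulfur, on an amine nitrogen whose other neighbours are a double-bonded nitrogen, gives a 1.1-fold lower number from compound 1 to compound 3 (0.05 log units; within the scatter) and so leaves the two compounds indistinguishable on this read-out. Within the data shown here, this is the only measurement at this part of the molecule, and it shows that an exchange of one atom, with the counts of heavy atoms, hydrogen-bond donors and hydrogen-bond acceptors all the same on both sides, need not move the number beyond the scatter, whereas the methyl on the saturated chain carbon gave a 3.4-fold lower number from compound 1 to compound 2 (0.53 log units; beyond the scatter) and did. Nothing available accounts for why the sulfur and oxygen compounds read alike here.

From the compounds shown here alone, one exchange at this nitrogen cannot show how much the position tolerates, so it remains open whether an acetyl group or a longer chain in place of the carbamoyl group would shift the number. Going by these compounds, it is also open whether the sulfur-for-oxygen exchange would read the same way on compound 2, which carries the extra methyl.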